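Hydroxymethyl in Place of Hydrogen on Compound 1

The compounds below may be only part of what the source reports. "The series", "measured", "known", "first", "only" and "open" are said of these compounds alone.

Compound 1 `CCn1c([C@@H](C)NS(=O)(=O)c2ccc(Cl)cc2)nc2ccccc21` gives > 100 mL.min-1.g-1 in an ADME assay (liver) for metabolic stability, with Liver microsome (Homo sapiens) as the target, read by LC-MS, using microsomes and NADPH, with a stated time of 5 min, at 37 degrees C (on this read-out higher numbers stand for fast clearance and lower numbers for slow clearance), as a limit of the assay and not as a number. Compound 4 `CCn1c([C@@H](C)NS(=O)(=O)c2ccc(Cl)cc2)nc2ccc(CO)cc21` differs from compound 1 by hydroxymethyl in place of hydrogen on an aromatic carbon. Two compounds bear on this change. Compound 3 `CCn1c([C@@H](C)NS(=O)(=O)c2ccc(Cl)cc2)nc2cc(CO)ccc21` carries the same exchange and gives 88 mL.min-1.g-1 in this assay while compound 2 `CCn1c([C@@H](C)NS(=O)(=O)c2ccc(Cl)cc2)nc2cc(C#N)ccc21` with cyano in place of hydrogen gives 71 mL.min-1.g-1 there. The measured steps are an at least 1.1-fold lower number from compound 1 to compound 3 (0.05 log units; that floor lies within the scatter) for hydroxymethyl and an at least 1.4-fold lower number from compound 1 to compound 2 (0.14 log units; that floor lies within the scatter) for cyano, and a 1.2-fold higher number from compound 2 to compound 3 (0.09 log units; within the scatter) separates the two. Because compound 3 gives 88 mL.min-1.g-1 after the same exchange, no clear shift beyond the scatter is expected for compound 4, and any shift should run toward a lower number. The estimated change is an at least 1.1-fold lower number from compound 1 to compound 4 (0.07 log units; that floor lies within the scatter) for this exchange. For compound 4 the estimate is 85 mL.min-1.g-1 with an expected range from 50 mL.min-1.g-1 to 135 mL.min-1.g-1 in this measurement.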

Compound 4, intrinsic clearance in microsomes: 84 mL.min-1.g-1
Compound 4: the middle estimate sits 1.0-fold (0.01 log units) above what was measured; low and high end bracket the measured number.
By their numbers in this assay, from the lowest: compounds 2, 4 and 3 (each within the scatter of the next). At a limit, above all of these: compound 1.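

In this assay, hydroxymethyl on this aromatic carbon gives an at least 1.1-fold lower number from compound 1 to compound 4 (0.07 log units; that floor lies within the scatter), so this position shows no shift that can be told from the scatter. Compound 4 carries the same group as compound 3 on a different aromatic carbon of the same six-membered ring, and the two values lie within the scatter of each other, so moving hydroxymethyl between these two carbons makes no visible difference. Compound 1 stands at a limit of the assay and not at a number: the limit of > 100 mL.min-1.g-1 in this assay, at which 1 of the 4 values shown sits.

From the compounds shown here alone, the true size of the step from compound 1 therefore stays open. The compounds shown also leave open whether an amine, a carboxylic acid or a longer chain on this aromatic carbon would move the intrinsic clearance beyond the scatter of compound 4.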